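Swapping the methoxyphenyl for a difluorophenyl on the chalcone arm

A few compounds are considered here, and "the series" means these few. Any claim that something is new, unique, unknown or untested is made for them only; others in the source may bear on it.

Compound 2, `COc1ccc(C(=O)/C=C/c2cc(-c3cc(OC)c(OC)c(OC)c3)n[nH]2)cc1`, carries a 4-methoxyphenyl group on the carbonyl carbon of the shared core. In a functional assay on OVCAR-4 cells (Homo sapiens) for inhibition, read by sulforhodamine B assay, with a stated time of 48 h (a lower number here means that less compound is tolerated, a higher number that more compound is tolerated), compound 2 gives > 100000 nM, which is a limit of the assay and not a number. Among the measured compounds shown here, its one measured neighbour, compound 1, `COc1ccc(C(=O)/C=C/c2cc(-c3cc(OC)c(OC)c(OC)c3)n[nH]2)cc1OC`, differs only by an additional methoxy group and gives 49900 nM. The step of an at least 2.0-fold higher number from compound 1 to compound 2 (0.30 log units; that floor lies within the scatter) therefore reaches only (the limit of > 100000 nM in this assay, at which 1 of the 2 values shown sits), and its floor lies within the scatter, so the two compounds cannot be ranked against each other.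

Compound 3, `COc1cc(-c2cc(/C=C/C(=O)c3ccc(F)c(F)c3)[nH]n2)cc(OC)c1OC`, is not yet measured. Its difference from compound 2 is 3,4-difluorophenyl in place of 4-methoxyphenyl on a carbonyl carbon. For the measured compounds named here, no measured step exchanges one aromatic ring for another; the only step known removes a single methoxy group and ends at a limit. The change to compound 3 removes the remaining methoxy group as well and adds two fluorines, so the expectation rests on compound 2 alone. The expected step of a number no higher from compound 2 to compound 3 (the limit leaves the size open) is therefore none beyond the scatter. For compound 3 in this assay the estimated value is 100000 nM, with a range from 30000 nM to 300000 nM, and a limit is again the likelier outcome.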

Compound 3, concentration lethal to 50% of the cells: > 100000 nM
Compound 3: a limit, no number (the forecaster's own chance of this, stated with the estimate: 60%); the middle value lies on the limit itself.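

Exchanging the 4-methoxyphenyl on the carbonyl carbon for 3,4-difluorophenyl leaves compound 3 at the same limit of this assay as compound 2, so the step between them cannot be read and the two cannot be ranked. Among the compounds shown here, the only step that can be read is an at least 2.0-fold higher number from compound 1 to compound 3 (0.30 log units; that floor lies within the scatter), for 3,4-difluorophenyl in place of 3,4-dimethoxyphenyl on a carbonyl carbon, and it reaches no further than the floor already seen on removing one methoxy group, so this exchange ranks nothing either. What is new is that a ring with no methoxy group at all at this place also ends at the limit, and what can be said of this position is now bounded by that limit: the limit of > 100000 nM in this assay, at which 2 of the 3 values shown sit.

As far as these compounds go, of the three compounds, only compound 1 gives a number, 49900 nM, so it stays open whether any group on this carbonyl carbon would give a clearly lower number than the others. From the compounds shown here alone, how a phenyl ring carrying a hydroxyl group, a dimethylamino group or a carboxylic acid would read in this assay also stays open.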